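Methoxy on the aromatic ring of a weak sigma ligand

The compounds below may be only part of what the source reports. "The series", "measured", "known", "first", "only" and "open" are said of these compounds alone.

Compound 1, `CC1(C)CCCN(CCCC2CCc3ccccc32)C1`, gives 6.9 nM in an assay on cell membranes for binding affinity to Sigma non-opioid intracellular receptor 1 (Rattus norvegicus), read by radioligand binding; on this read-out lower numbers stand for stronger inhibition and higher numbers for weaker inhibition.
Compound 2, `CC1(C)CCCN(CCCC2CCCc3ccccc32)C1`, gives 252 nM in this assay.
Compound 3, `CC1(C)CCCN(CCCCCC2CCCc3ccccc32)C1`, gives 1520 nM in this assay.

Compound 3 stands at the highest of the measured numbers: compound 2 sits at a lower number, beyond the scatter, and compound 1 sits at a still lower number, far beyond it. For the measured compounds named here, no single-change step between measured compounds is available, so the comparison with compound 3 rests on these values alone.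

Compound 4, `COc1ccc2c(c1)CCCC2CCCCCN1CCCC(C)(C)C1`, differs from compound 3 in one place: methoxy in place of hydrogen on an aromatic carbon. Going by the values given here, nothing among the measured compounds shows what a methoxy at such a position does in this assay, so no direction can be read from the data. The expected step from compound 3 to compound 4 is therefore a 1.0-fold lower number from compound 3 to compound 4 (0.01 log units; within the scatter), that is, none beyond the scatter. Compound 4 is estimated at 1500 nM, with a range from 500 nM to 5000 nM.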

Compound 4, half-maximal inhibitory concentration: 0.62 nM
Compound 4: middle estimate off by 2400-fold (3.38 log units), on the high side; the whole stated range lies above it.
By their numbers in this assay, from the lowest: compound 4; then compound 1; then compound 2; then compound 3.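

Methoxy in place of hydrogen on this aromatic carbon, meta to a fused ring and para to a fused ring, brings a 2500-fold lower number from compound 3 to compound 4 (3.39 log units; beyond the scatter) in this assay, a large step. The earlier compounds shown here carry only hydrogen on this ring, so they gave no reading of this position; this step shows that affinity here is highly sensitive to a single small change on the aromatic ring. The data at hand offer nothing that accounts for a step of this size.

On these data alone, whether a hydroxy group or a fluorine atom on the same carbon, or a methoxy group on another carbon of the aromatic ring, would give a step of similar size remains open. As far as these compounds go, it is equally open whether methoxy would act in the same way on the shorter chain of compound 2 or on the core of compound 1.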